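The compounds below may be only part of what the source reports. "The series", "measured", "known", "first", "only" and "open" are said of these compounds alone.

In a functional assay on MCF7 cells (Homo sapiens) for cytotoxicity, read by MTT assay, with a stated time of 48 h (on this read-out higher numbers stand for weaker inhibition and lower numbers for stronger inhibition), compound 1 `Fc1cccc(Nc2nc(-c3cccc(F)c3)nc3ccc(F)cc23)c1` gives 48700 nM. Compound 2 `Fc1cccc(-c2nc(Nc3ccc(Cl)cc3)c3cc(F)ccc3n2)c1` differs from it by 4-chlorophenyl in place of 3-fluorophenyl on a nitrogen on an aromatic ring. In this assay compound 2 returns only a limit, > 50000 nM, so no number is known for it; this is the limit of > 50000 nM in this assay, at which 1 of the 2 values shown sits. Compound 3 `Fc1cccc(-c2nc(Nc3ccccc3Cl)c3cc(F)ccc3n2)c1` follows with the change (2-chlorophenyl in place of 4-chlorophenyl on a nitrogen on an aromatic ring). Among the measured compounds shown here, the only measured step that bears on this position is an at least 1.0-fold higher number from compound 1 to compound 2 (0.01 log units; that floor lies within the scatter), a change within the scatter that carried the read-out to its limit and gives no sign of a gain in either direction. On that basis compound 3 is expected to show a step that the limit leaves unreadable from compound 2 to compound 3, which is no step beyond the scatter. The estimate for compound 3 in this assay is 55000 nM, with a range from 25000 nM to 120000 nM, and a result reported once more as a limit rather than a number would fit this expectation.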

Compound 3, half-maximal inhibitory concentration: > 50000 nM
Compound 3: only a limit was reported; the forecaster's own chance of this, stated with the estimate: 55%; the middle value does not contradict the limit.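

In this assay compound 3 also returns only a limit, > 50000 nM, and not a number. The step from the 4-chlorophenyl to the 2-chlorophenyl cannot be read, as both of its ends are limits, so the new result adds a second chlorophenyl on this nitrogen without showing whether the place of the chlorine matters. Set against 3-fluorophenyl, the 2-chlorophenyl gives an at least 1.0-fold higher number from compound 1 to compound 3 (0.01 log units; that floor lies within the scatter), which, like the step to the 4-chlorophenyl, shows no gain in either direction, and the series now stands as follows: the limit of > 50000 nM in this assay, at which 2 of the 3 values shown sit.

The compounds shown leave open whether the two chlorophenyl compounds truly differ in this assay, and whether any group on this nitrogen can bring the read-out clearly lower than it is for compound 1. Compound 1 gives 48700 nM. They also leave open what a phenyl ring bearing a methoxy group, an amine or a carboxylic acid would give here, or a saturated chain such as butyl in place of the ring.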